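This account rests on a few compounds, and the source may have more. Where it says the series, first, only, none or still open, it means among the compounds named here.

Measured compounds:
Compound 1, `COC(=O)C1=C(CN2CCOCC2=O)NC(c2nccs2)=NC1(C)c1ccc(F)cc1`, gives 80 mL/min/kg in an ADME assay on microsomes from liver (Mus musculus) for metabolic stability, read by LC-MS, using NADPH, with stated times of 10 min and 30 min, tested at 1 uM; a higher number here means faster removal of the compound, a lower number slower removal.
Compound 2, `COC(=O)C1=C(CN2CCC(O)C2)NC(c2nccs2)=NC1(C)c1ccc(F)cc1`, gives 83 mL/min/kg in this assay.
Compound 3, `COC(=O)C1=C(Cn2ccnc2)NC(c2nccs2)=NC1(C)c1ccc(F)cc1`, gives 69 mL/min/kg in this assay.

The three compounds share one core and differ only in the group on a saturated chain carbon bound to a double-bonded ring carbon. Compound 3 stands within the scatter of both others: a 1.2-fold lower number from compound 1 to compound 3 (0.06 log units; within the scatter) and a 1.2-fold lower number from compound 2 to compound 3 (0.08 log units; within the scatter), and likewise a 1.0-fold higher number from compound 1 to compound 2 (0.02 log units; within the scatter). Compound 4, `COC(=O)C1=C(COC2CCOC2)NC(c2nccs2)=NC1(C)c1ccc(F)cc1`, is not yet measured in this assay. It differs from compound 3 at the same position: (oxolan-3-yl)oxy in place of 1H-imidazol-1-yl on a saturated chain carbon bound to a double-bonded ring carbon.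

All three measured steps bear on this change, since each swaps the group at this very position, and none moved the number beyond the scatter. The new group is again a small ring carrying two hydrogen-bond acceptors and no donor, so no step beyond the scatter is expected in this assay either: a 1.1-fold higher number from compound 3 to compound 4 (0.05 log units; within the scatter) is the estimated step. Compound 4 is therefore expected to give about 78 mL/min/kg, with a range from 45 mL/min/kg to 135 mL/min/kg.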

Compound 4, clearance: 79 mL/min/kg
Estimate against measurement, compound 4: 1.0-fold (0.01 log units) below, within the range that was stated.
By their numbers in this assay, from the lowest: compounds 3, 4, 1 and 2 (each within the scatter of the next).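

In this assay, the earlier groups were all bound through a ring nitrogen, whereas (oxolan-3-yl)oxy contains no nitrogen and has a non-aromatic ring, yet the step stays within the scatter against each of them (a 1.1-fold higher number from compound 3 to compound 4 (0.06 log units; within the scatter); a 1.1-fold lower number from compound 2 to compound 4 (0.02 log units; within the scatter); a 1.0-fold lower number from compound 1 to compound 4 (0.01 log units; within the scatter)). On a saturated chain carbon bound to a double-bonded ring carbon, all four compounds therefore lie within the scatter of one another, and compound 4 goes against no part of that pattern. No measurement shown explains why these groups give such close numbers.

The compounds leave open whether a carboxylic acid, a primary amine or a longer open chain at this place would give a step beyond the scatter. From the compounds shown here alone, what a change elsewhere on the shared core would do also remains open.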